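The source may report more compounds than this note shows. Statements on the series, on what has been measured and on what is new or still open speak of the compounds shown alone.

Three compounds have been measured in an assay on HEK293 cells for inhibition of Voltage-dependent N-type calcium channel subunit alpha-1B (Homo sapiens), read by fluorescence and calcium flux, with a stated time of 5 min; on this read-out higher numbers stand for weaker inhibition and lower numbers for stronger inhibition:

Compound 1 `COc1ccccc1-n1nc(C2CC(C)(C)OC(C)(C)C2)cc1-c1ccnc(Cl)c1`: 11 nM
Compound 2 `COc1ccccc1-n1nc([C@H]2C[C@@H](C)O[C@@H](C)C2)cc1-c1ccc(Cl)cc1`: 3 nM
Compound 3 `COc1ccccc1-n1nc(C2CC(C)(C)OC(C)(C)C2)cc1-c1ccc(C#N)cc1`: 1 nM

Compound 2 holds the second highest of the three numbers. Its nearest neighbour is compound 3, whose number is lower, and the gap between them is beyond the scatter; compound 1 is furthest from it, with a higher number, again beyond the scatter. Compound 2 therefore sits between the other two.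

Compound 4 `COc1ccccc1-n1nc(C2CCOC(C)(C)C2)cc1-c1ccc(Cl)cc1` is not yet measured. It differs from compound 2 in one place: 2,2-dimethyloxan-4-yl in place of 2,6-dimethyloxan-4-yl on an aromatic carbon. The two have the same atoms, joined differently.

Going by the values given here, the only measured step, an 11-fold lower number from compound 1 to compound 3 (1.04 log units; beyond the scatter), is a large one, but it alters the aromatic group on the shared core while the oxane ring stays the same. Among the compounds with values here, it does not bear on the change from compound 2 to compound 4, and the data hold no step that changes the oxane substituent. With nothing to point either way, no step beyond the scatter in this assay is expected, which is what a 1.3-fold higher number from compound 2 to compound 4 (0.12 log units; within the scatter) means here. Compound 4 is therefore estimated at 4 nM, with a range from 1.5 nM to 12 nM.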

Compound 4, half-maximal inhibitory concentration: 2 nM
For compound 4 the middle estimate is 2.0-fold (0.30 log units) above the measured one; low and high end bracket the measured number.
By their numbers in this assay, from the lowest: compounds 3, 4 and 2 (each within the scatter of the next, the first and the last beyond it); then compound 1.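

In this assay, putting 2,2-dimethyloxan-4-yl in place of 2,6-dimethyloxan-4-yl on the aromatic carbon of the five-membered ring gives a 1.5-fold lower number from compound 2 to compound 4 (0.18 log units; within the scatter). This is the first step shown at this position, and it shows that, with the 4-chlorophenyl group held constant, this rearrangement of the same atoms on the oxane ring leaves the number within the scatter, even though the group that leaves carries 3 defined stereocentres and the group that enters has none defined. No measurement on hand speaks to why the two groups cannot be told apart in this assay.

From the compounds shown here alone, both groups at this position are dimethyl-substituted oxanes, so what a piperidin-4-yl or a cyclohexyl group would do there remains open, and so does whether the ring oxygen or the methyl groups matter at all. Going by these compounds alone, also open is whether the same tolerance holds when the 4-chlorophenyl group gives way to the 4-cyanophenyl or 2-chloropyridin-4-yl group, since this one pair is the only comparison at this position.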